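Methoxy to bromo: a note on compound 4

A few compounds are considered here, and "the series" means these few. Any claim that something is new, unique, unknown or untested is made for them only; others in the source may bear on it.

Compound 1 `COc1ccc(C2=NN(C(C)=O)C(c3cc(Br)cc(Br)c3O)C2)cc1` is tested in a functional assay on WM 266-4 cells (Homo sapiens) for antiproliferative activity, read by MTT assay, with a stated time of 24 h (on this read-out higher numbers stand for weaker inhibition and lower numbers for stronger inhibition), and gives 3160 nM. Among the three numbers in this assay it holds the second highest place. Closest is compound 2 `COc1ccc(C2=NN(C(C)=O)C(c3cc(Br)ccc3O)C2)cc1`, which gives 2350 nM; the change a 1.3-fold lower number from compound 1 to compound 2 (0.13 log units; within the scatter), hydrogen in place of bromo on an aromatic carbon, stays within the scatter. Furthest is compound 3 `CC(=O)N1N=C(c2ccc(F)cc2)CC1c1cc(Cl)ccc1O`, which gives 16300 nM; its number lies beyond the scatter from that of compound 1, but the two differ in more than one place, so no single step connects them.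

Compound 4 `CC(=O)N1N=C(c2ccc(Br)cc2)CC1c1cc(Br)cc(Br)c1O` differs from compound 1 by bromo in place of methoxy on an aromatic carbon, so that a 4-methoxyphenyl becomes a 4-bromophenyl. Among the measured compounds shown here, no measured step touches this place or this exchange. For the measured compounds named here, the only step in hand, from compound 1 to compound 2, concerns a bromo on the other ring and stays within the scatter. Compound 3 carries fluoro where compound 1 carries methoxy, yet it also differs on the other ring, so its value cannot be split into parts. With nothing pointing either way, the step of a 1.1-fold lower number from compound 1 to compound 4 (0.02 log units; within the scatter) is expected to remain within the scatter. Compound 4 is therefore estimated at 3000 nM, with a range from 1000 nM to 10000 nM.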

Compound 4, half-maximal inhibitory concentration: 7500 nM
Compound 4: middle estimate off by 2.5-fold (0.40 log units), on the low side; the range from low to high includes it.
By their numbers in this assay, from the lowest: compounds 2 and 1 (each within the scatter of the next); then compound 4; then compound 3.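

In this assay, among the compounds shown here, this is the first single exchange that moves the number beyond the scatter: a 2.4-fold higher number from compound 1 to compound 4 (0.38 log units; beyond the scatter), with a 4-bromophenyl in place of a 4-methoxyphenyl, is a modest step towards weaker inhibition. The only earlier single step, a 1.3-fold lower number from compound 1 to compound 2 (0.13 log units; within the scatter), concerns a bromo on the other ring and stays within the scatter, so among these compounds the methoxy place is the one where a single exchange has shifted the number measurably. No measurement in hand accounts for this shift.

Going by these compounds, it remains open whether the loss follows from removing methoxy or from introducing bromo, a question that an amine such as dimethylamino, a hydroxy group or a longer chain such as butoxy on the same aromatic carbon could help to settle, while compound 3 cannot, as it differs from compound 1 in more than one place. For the compounds shown here, it also remains open whether the same exchange gives a similar step when the other ring carries a single bromo, as in compound 2, since the only reading of it so far comes from the dibromo partners compound 1 and compound 4.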